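This account rests on a few compounds, and the source may have more. Where it says the series, first, only, none or still open, it means among the compounds named here.

Of the compounds shown here, three have so far been measured in an assay on isolated protein for inhibition of myosin-2 (Bos taurus), read by spectrophotometry, with a stated time of 24 min; a lower number here means a stronger inhibitor, a higher number a weaker inhibitor. Compound 1 `CCCCCC/N=C(\C)c1c(O)c2ccccc2oc1=O` gives 2900 nM. Compound 2 `C/C(=N\CCO)c1c(O)c2ccccc2[nH]c1=O` reaches only the limit of >= 100000 nM, so no number is known for it. Compound 3 `C/C(=N\CC1CCCCC1)c1c(O)c2ccccc2[nH]c1=O` likewise stops at the limit of >= 100000 nM. These two sit at the limit of >= 100000 nM in this assay, at which 2 of the 3 values shown sit. The step that the two limits leave unreadable from compound 2 to compound 3 therefore cannot be sized, and compound 3 stands at the weak end of what the numbers show, without a value of its own to anchor any comparison. Compound 4 `CCC(C)/N=C(\C)c1c(O)c2ccccc2[nH]c1=O` differs from compound 3 by sec-butyl in place of cyclohexylmethyl on a double-bonded nitrogen. For the measured compounds named here, no measured step bears on this change in a readable way, since the only measured step on this shared core is hidden by the limit. On that basis compound 4 is expected to stay close to where compound 3 stands, with a number no higher from compound 3 to compound 4 (the limit leaves the size open) estimated as no step beyond the scatter. Compound 4 is therefore estimated at 100000 nM, within 30000 nM to 300000 nM, with a substantial chance that it too is reported only as a limit.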

Compound 4, half-maximal inhibitory concentration: >= 100000 nM
Compound 4: only a limit was reported; the forecaster's own chance of this, stated with the estimate: 75%; the middle value sits exactly at the limit.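

In this assay, for the compounds shown here, compound 4 gives >= 100000 nM, which is a limit, so no step linking compound 2, compound 3 and compound 4 can be read: the limit of >= 100000 nM in this assay, at which 3 of the 4 values shown sit. The compounds shown leave open how far any of these chain changes on the shared core shifts inhibition.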